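A few compounds are considered here, and "the series" means these few. Any claim that something is new, unique, unknown or untested is made for them only; others in the source may bear on it.

Three compounds share one core and differ only in the groups attached to it. Compound 1 `C=CCN1C(=O)C(=O)c2cc(-c3ccc(OC)cc3)ccc21` gives 390 nM in a functional assay on K562 cells (Homo sapiens) for antiproliferative activity, read by MTT assay, with a stated time of 48 h; a higher number here means a weaker inhibitor, a lower number a stronger inhibitor. Compound 2 `COc1ccc(-c2ccc3c(c2)C(=O)C(=O)N3Cc2cccc(OC)c2)cc1` gives 680 nM in this assay, and compound 3 `COc1ccc(CN2C(=O)C(=O)c3cc(-c4cc(OC)cc(OC)c4)ccc32)cc1` gives 510 nM in this assay. The value of compound 3 lies within the usual scatter of both compound 1 and compound 2, so the three cannot be told apart on these numbers. Among the compounds with values here, the only single change among them, a 1.7-fold higher number from compound 1 to compound 2 (0.24 log units; within the scatter), alters the group on the ring nitrogen and stays within the scatter. Compound 4 `COc1ccc(CN2C(=O)C(=O)c3cc(-c4ccc(C#N)cc4)ccc32)cc1` differs from compound 3 at the aromatic group: 4-cyanophenyl in place of 3,5-dimethoxyphenyl on an aromatic carbon. Within the data shown here, no measured step touches that place directly, and compound 2 and compound 3, which carry different groups there, show values within the scatter of each other. For compound 4 the expected step is therefore a 1.0-fold lower number from compound 3 to compound 4 (0.01 log units; within the scatter), nothing beyond the scatter. Compound 4 is estimated to give 500 nM in this assay, with a range from 200 nM to 1300 nM.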

Compound 4, half-maximal inhibitory concentration: 260 nM
For compound 4 the middle estimate is 1.9-fold (0.28 log units) above the measured one; measured number inside the range.
By their numbers in this assay, from the lowest: compounds 4, 1, 3 and 2 (each within the scatter of the next, the first and the last beyond it).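

Within the data shown here, this is the first step that changes only the aromatic group, and in this assay it comes to a 2.0-fold lower number from compound 3 to compound 4 (0.29 log units; within the scatter). Replacing the two methoxy groups of 3,5-dimethoxyphenyl with the single nitrile of 4-cyanophenyl therefore gives no change that can be told from repeat-measurement scatter, so this position accepts both groups on the shared core with the same 4-methoxybenzyl group on the ring nitrogen. Nothing presented here gives a reason for this result.

Because the swap alters both the substituent and where it sits on the phenyl ring, these compounds cannot show which of the two matters. Going by these compounds, it also remains open how this position would respond to a plain phenyl ring, or to a phenyl ring carrying an amine or a carboxylic acid.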